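The compounds below may be only part of what the source reports. "The series", "measured", "known", "first", "only" and "open" are said of these compounds alone.

Compound 1 `COc1ccc(OC)c(CNc2ncnc3c2ncn3C2CCCCO2)c1` in an ADME assay on K562 cells (Homo sapiens) for cytotoxicity, with a stated time of 72 h (a lower number here means a stronger inhibitor, a higher number a weaker inhibitor), gives 16500 nM. Compound 2 `COc1cc(OC)c(OC)cc1CNc1ncnc2c1ncn2C1CCCCO1` carries the change (methoxy in place of hydrogen on an aromatic carbon). In this assay compound 2 returns only the limit > 100000 nM. The step of an at least 6.0-fold higher number from compound 1 to compound 2 (0.78 log units; beyond the scatter) is therefore known only as a minimum, because of the limit of > 100000 nM in this assay, at which 2 of the 3 values shown sit.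

Compound 3 `COc1cc(CNc2ncnc3c2ncn3C2CCCO2)cc(OC)c1` differs from compound 1 in its core; the difference between the two cores is not broken down here. In this assay compound 3 likewise gives only the limit > 100000 nM.

Compound 4 `COc1cc(CNc2ncnc3c2ncn3C2CCCO2)cc(OC)c1OC` is not yet measured and carries the change (methoxy in place of hydrogen on an aromatic carbon). For the measured compounds named here, this is the same kind of change as the one from compound 1 to compound 2, not the same: in compound 2 the entering methoxy stands ortho to a methoxy group, meta to a methoxy group and para to a large group, whereas in compound 4 it stands ortho to two methoxy groups and para to a large group.

Since compound 3 already sits at the limit and the comparable step an at least 6.0-fold higher number from compound 1 to compound 2 (0.78 log units; beyond the scatter) ran toward a weaker inhibitor, the step expected from compound 3 to compound 4 in this assay is a step that the limit leaves unreadable from compound 3 to compound 4, at best flat and more likely upward. Compound 4 is expected to give 200000 nM in this assay, with a range of 70000 nM to 600000 nM, most probably reported again as a limit.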

Compound 4, half-maximal inhibitory concentration: > 100000 nM
Compound 4: only a limit was reported (the forecaster's own chance of this, stated with the estimate: 85%); the middle value is on the limit's open side.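

In this assay compound 4 gives > 100000 nM, which is a limit and not a number. Compound 3 also stands at a limit, so no size can be read for the methoxy change from compound 3 to compound 4, because both compounds sit at the same limit: the limit of > 100000 nM in this assay, at which 3 of the 4 values shown sit.

The compounds shown leave open whether this methoxy has any effect on cytotoxicity and how compounds 2, 3 and 4 rank among themselves.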